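This account rests on a few compounds, and the source may have more. Where it says the series, first, only, none or still open, it means among the compounds named here.

Of the compounds shown here, two have numbers so far in a functional assay on KB cells (Homo sapiens) for cytotoxicity (on this read-out higher numbers stand for weaker inhibition and lower numbers for stronger inhibition), and that is little to reason from. Compound 1 `CCCOC1=CC(=O)c2ccccc2C1=O` reads 49400 nM here, the higher number of the two and so the weaker inhibition. Compound 2 `C=CCOc1ccc2c(c1)C(=O)C=CC2=O` reads 10200 nM here, which is lower by more than the usual scatter of repeat measurements. Among the measured compounds shown here, no measured pair differs in one place only, so the data give no direct guide to the size of a single small change.

The next compound is compound 3 `CCCCOC1=CC(=O)c2ccccc2C1=O` and it differs from compound 1 at the end of the chain: methyl in place of hydrogen on a saturated chain carbon, three bonds along the chain from an oxygen on an unsaturated carbon on a saturated chain carbon, three bonds along the chain from an oxygen on an unsaturated carbon, so that propyl becomes butyl. A change this small is expected to shift the number only modestly in this assay and the expected direction is slightly downward, possibly staying within the scatter. The step expected is a 1.4-fold lower number from compound 1 to compound 3 (0.14 log units; within the scatter) and this remains an estimate. Compound 3 is expected to read 36000 nM (estimated range 13000 nM to 90000 nM).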

Compound 3, half-maximal inhibitory concentration: 27000 nM
Beside the measured number, compound 3's estimate is 1.3-fold (0.12 log units) above it, and the stated range covers the measured number.
By their numbers in this assay, from the lowest: compound 2; then compounds 3 and 1 (each within the scatter of the next).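

Among the compounds shown here, compound 1 and compound 3 are the first pair here that differ in one place only, so they give the first direct measure of a single small change. In this assay, putting methyl in place of hydrogen on a saturated chain carbon, three bonds along the chain from an oxygen on an unsaturated carbon, turns propyl into butyl and gives a 1.8-fold lower number from compound 1 to compound 3 (0.26 log units; within the scatter). This step lies within the usual scatter of repeat measurements, so the propyl and butyl chains at this position cannot be told apart on this read-out, and no measurement at hand offers an explanation for the result.

As far as these compounds go, whether a longer chain such as hexyl, or a chain ending in an amine or a carboxylic acid, would give a step beyond the scatter at this position remains open. Also open, from the compounds shown here alone, is whether the same change, made on the shorter chains as methyl to ethyl or ethyl to propyl, would give a step of similar size.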